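The source may report more compounds than this note shows. Statements on the series, on what has been measured and on what is new or still open speak of the compounds shown alone.

Measured compounds:
Compound 1, `COc1ccccc1/C=C1\CCC/C(=C\c2cccc(OC)c2OC)C1=O`, > 20000 nM
Compound 2, `COc1ccc(/C=C2\CCC/C(=C\c3cccc(Cl)c3)C2=O)cc1OC`, 11000 nM

The study reads growth of lung-derived cells in a functional assay on A549 cells (Homo sapiens) for cytotoxicity, read by MTT assay, with a stated time of 72 h; on this read-out lower numbers stand for stronger inhibition and higher numbers for weaker inhibition. For compound 1 the result is a limit of the assay rather than a number, (the limit of > 20000 nM in this assay, at which 1 of the 2 values shown sits). For the measured compounds named here, compound 2 is therefore the only compound with a measured number in this assay, where compound 2 gives 11000 nM. Going by the values given here, with only one number at hand, nothing can be said of a difference between the two compounds.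

Compound 3 is `COc1ccc(/C=C2\CCC/C(=C\c3ccc(O)c(O)c3)C2=O)cc1OC`. It differs from compound 2 by 3,4-dihydroxyphenyl in place of 3-chlorophenyl on a double-bonded chain carbon bound to a double-bonded ring carbon. Among the compounds with values here, no step between measured compounds is available to guide the expectation, so the size of the change in this assay is judged only from the replacement of one aromatic group by another that carries hydroxyls. A modest shift is expected, not clearly beyond the scatter, and its direction is uncertain; the expected step is a 1.2-fold lower number from compound 2 to compound 3 (0.09 log units; within the scatter). Compound 3 is thus estimated at 9000 nM, with a range from 3000 nM to 25000 nM.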

Compound 3, half-maximal inhibitory concentration: > 20000 nM
Compound 3: no number, only a limit (the forecaster's own chance of this, stated with the estimate: 25%); at least 2.2-fold (0.34 log units) between middle value and limit.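

In this assay compound 3 gives > 20000 nM, which is a limit of the assay and not a number. Putting 3,4-dihydroxyphenyl in place of 3-chlorophenyl on a double-bonded chain carbon bound to a double-bonded ring carbon gives an at least 1.8-fold higher number from compound 2 to compound 3 (0.25 log units; that floor lies within the scatter), so this change did not lower the number, and the step has only a floor, leaving its true size unknown. This is the first step that can be read at this place, and it leaves compound 2 as the only compound shown with a number, while the other readings stop at the same limit: the limit of > 20000 nM in this assay, at which 2 of the 3 values shown sit.

The compounds shown leave open how far compound 3 actually lies from compound 2, and whether the hydroxyls or the loss of the chlorine accounts for the step, since no plain phenyl or single hydroxyl group stands at this place for comparison. They also leave open what an amine, a carboxylic acid or a methoxy group at this place would give on the same core.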